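Trimming the Ethyl Arm in a Glioblastoma Cell Series

The source may report more compounds than this note shows. Statements on the series, on what has been measured and on what is new or still open speak of the compounds shown alone.

Measured so far:
compound 1 `CCc1ccc(C(Nc2ccccn2)c2ccc3cccnc3c2O)cc1` — 9300 nM
compound 2 `Cc1ccnc(NC(c2ccc(C(F)(F)F)cc2)c2ccc3cccnc3c2O)c1` — 2100 nM

Of the compounds shown here, two sharing one core have been tested in a functional assay on U-87MG ATCC cells for inhibition, with U-87 MG (Homo sapiens) as the target, read by MTT assay, with a stated time of 72 h; a lower number here means a stronger inhibitor, a higher number a weaker inhibitor. Compound 1 gives 9300 nM, the highest number of the two. Compound 2 gives 2100 nM in this assay, a lower number than compound 1 by a margin beyond the usual scatter; the two differ in several places at once, so no single change can be credited for that gap.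

Compound 3, `Cc1ccc(C(Nc2ccccn2)c2ccc3cccnc3c2O)cc1`, differs from compound 1 in one place: hydrogen in place of methyl on a saturated chain carbon bound to an aromatic carbon. For the measured compounds named here, the group that leaves is a single carbon, and no measured pair shows this change on its own. With so little removed, the step of a 1.1-fold higher number from compound 1 to compound 3 (0.03 log units; within the scatter) is expected to stay within the scatter, with no clear direction. Compound 3 is therefore expected to come in near 10000 nM, between 4000 nM and 25000 nM.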

Compound 3, half-maximal inhibitory concentration: > 10000 nM
Compound 3: no number, only a limit (the forecaster's own chance of this, stated with the estimate: 10%); the middle value lies on the limit itself.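

In this assay compound 3 gives > 10000 nM, which is a limit of the assay and not a number. The change from 4-ethylphenyl to 4-methylphenyl is the only single-place step shown at this position, and it reads only as an at least 1.0-fold higher number from compound 1 to compound 3 (0.03 log units; that floor lies within the scatter). Whether this change leaves the value where it was or raises it cannot be told, and the reading stops at the end of what the assay reports: the limit of > 10000 nM in this assay, at which 1 of the 3 values shown sits.

The compounds shown leave open how the value responds to a different group in place of the ethyl, such as a methoxy group, a chlorine atom or a longer chain such as propyl. From the compounds shown here alone, the size of the step itself also stays open, with only a floor to go on.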